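Hydroxyphenyl to nitrooxyphenyl on a shared hydrazone core

The source may hold more compounds than are shown below. What is called first, only, known or untested is meant among the compounds shown, and "the series" means these compounds.

Measured so far:
Compound 1, `CN(C)CCn1cnnc1-c1cc(Oc2ccc(NC(=O)N/N=C/c3cccc(O)c3)cc2F)ccn1`: in an ADME assay on WI-38 cells (Homo sapiens) for cytotoxicity, read by MTT assay, with a stated time of 72 h (on this read-out lower numbers stand for stronger inhibition and higher numbers for weaker inhibition), compound 1 gives "not determined" (no result reported)
Compound 2, `CN(C)CCn1cnnc1-c1cc(Oc2ccc(NC(=O)N/N=C/c3c[nH]c4ccccc34)cc2F)ccn1`: in this assay compound 2 gives 3620 nM

Compound 1 stands nowhere on these numbers, since it has no value of its own; only compound 2 provides a measured point. Compound 3, `CN(C)CCn1cnnc1-c1cc(Oc2ccc(NC(=O)N/N=C/c3ccccc3O[N+](=O)[O-])cc2F)ccn1`, differs from compound 1 by 2-(nitrooxy)phenyl in place of 3-hydroxyphenyl on a carbon with a double bond to nitrogen. Within the data shown here, with no measured step to lean on, the change to compound 3 is expected to move this assay by no more than the usual scatter, in no clear direction. For compound 3 a value near 4000 nM is expected, in the range 1500 nM to 12000 nM.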

Compound 3, half-maximal inhibitory concentration: 6860 nM
Estimate against measurement, compound 3: 1.7-fold (0.23 log units) below; low and high end bracket the measured number.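

In this assay replacing 1H-indol-3-yl with 2-(nitrooxy)phenyl on a carbon with a double bond to nitrogen gives a step (a 1.9-fold higher number from compound 2 to compound 3 (0.28 log units; within the scatter)), so these two quite different groups cannot be told apart here. The step from compound 1 to compound 3 cannot be read, as compound 1 has no value. No available evidence bears on this result. Still open, going by these compounds, is where the 3-hydroxyphenyl group of compound 1 would fall in this assay, and how a phenyl ring carrying a carboxylic acid or an amine would behave on the same carbon.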